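The source may report more compounds than this note shows. Statements on the series, on what has been measured and on what is new or still open speak of the compounds shown alone.

- compound 1 `C=C(Br)C(=O)Nc1cccc(/C=C/C(=O)Nc2ccc(F)cc2)c1`: 4800 nM
- compound 2 `C=C(Br)C(=O)Nc1cccc(/C=C/C(=O)NCc2ccc(C)cc2)c1`: 1900 nM

Among the compounds with values here, in a functional assay on LoVo cells (Homo sapiens) for inhibition, read by MTT assay, with a stated time of 72 h (a lower number here means a stronger inhibitor, a higher number a weaker inhibitor), compound 1 gives 4800 nM, the higher of the two numbers so far, which makes it the weaker inhibitor of the pair. The next compound to be tested is compound 3 `C=C(Br)C(=O)Nc1cccc(/C=C/C(=O)Nc2ccc(OC(F)(F)F)cc2)c1`. It keeps the core of compound 1 and changes one group: trifluoromethoxy in place of fluoro on an aromatic carbon. Trifluoromethoxy takes the place of fluoro on an aromatic carbon, para to a large group.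

Within the data shown here, only one measured step offers any guide, a 2.5-fold lower number from compound 1 to compound 2 (0.40 log units; beyond the scatter). This modest step, beyond the usual scatter, involves a different change at a different place, so it bears only loosely on compound 3. It shows that replacing one group on the shared core can shift the number modestly, but it does not settle the direction for this new change. With so little evidence, a modest shift is expected, leaning slightly towards a lower number, though a higher one remains possible. The expected change is a 1.5-fold lower number from compound 1 to compound 3 (0.18 log units; within the scatter). Compound 3 is estimated at 3200 nM, with an expected range from 1300 nM to 7500 nM.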

Compound 3, half-maximal inhibitory concentration: 30300 nM
The estimate for compound 3 lay 9.5-fold (0.98 log units) below the measured number; measured number outside the range, above it.
By their numbers in this assay, from the lowest: compound 2; then compound 1; then compound 3.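

This position is not indifferent to what sits on it: in this assay, putting trifluoromethoxy in place of fluoro on an aromatic carbon, para to a large group, gives a 6.3-fold higher number from compound 1 to compound 3 (0.80 log units; beyond the scatter) and so a clearly weaker inhibitor. The entering group has five heavy atoms where the leaving one has a single atom, and it adds one hydrogen-bond acceptor, so a larger group here goes with a weaker result in this one pair. The earlier step, a 2.5-fold lower number from compound 1 to compound 2 (0.40 log units; beyond the scatter), changed the group on an amide-type nitrogen and moved the number the other way, so single changes to compound 1 have now moved it in both directions, but the data offer no measured explanation for the rise seen with trifluoromethoxy.

With only fluoro and trifluoromethoxy shown at this position, it remains open how a smaller step such as methoxy, methyl or chlorine would read, or how an amine would. Going by these compounds, it is also open whether trifluoromethoxy would raise the number in the same way on a compound carrying the 4-methylbenzyl group of compound 2.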